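A few compounds are considered here, and "the series" means these few. Any claim that something is new, unique, unknown or untested is made for them only; others in the source may bear on it.

Compound 1 `Cc1nc(-c2cccnc2)sc1-c1nnc(-c2ccc(Br)cc2)o1`: > 100 ug/mL
Compound 2 `Cc1nc(-c2cccnc2)sc1-c1nnc(-c2ccccc2Cl)o1`: > 100 ug/mL

In an ADME assay on HeLa cells (Homo sapiens) for cytotoxicity, read by MTT assay (a higher number here means that more compound is tolerated, a lower number that less compound is tolerated), compound 2 gives > 100 ug/mL, which is a limit of the assay and not a number. Compound 1 gives > 100 ug/mL, which is also a limit. Neither compound therefore has an exact value, and the record so far is the limit of > 100 ug/mL in this assay, at which 2 of the 2 values shown sit.

Compound 3 `Cc1nc(-c2cccnc2)sc1-c1nnc(-c2cccc(Cl)c2Cl)o1` keeps the core of compound 2 and turns 2-chlorophenyl into 2,3-dichlorophenyl. It has chloro in place of hydrogen on an aromatic carbon, ortho to a chloro group and meta to a large group: chloro in place of hydrogen on an aromatic carbon.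

Within the data shown here, only one measured step bears on this change, a step that the two limits leave unreadable from compound 1 to compound 2. It also alters the halogen-bearing phenyl group, but it gives no size to carry over. The data therefore offer no sign of a change in either direction, and the new chloro group is expected to cause no shift beyond the scatter. The expected step is a number no higher from compound 2 to compound 3 (the limit leaves the size open). For compound 3 the estimated value is 100 ug/mL. The expected range for compound 3 runs from 40 ug/mL to 200 ug/mL, and the assay may well report only a limit again.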

Compound 3, half-maximal cytotoxic concentration: > 100 ug/mL
Compound 3 gave a limit, no number; the forecaster's own chance of this, stated with the estimate: 70%; the middle value lies on the limit itself.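

In this assay, compound 3 gives > 100 ug/mL, which is a limit of the assay and not a number, so the steps to compound 3 from compound 1 and from compound 2 cannot be read. All three compounds share one result: the limit of > 100 ug/mL in this assay, at which 3 of the 3 values shown sit.

The compounds shown leave open the exact concentration at which any of them harms these cells, and whether swapping the substituents on the phenyl group changes that concentration at all.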